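The compounds below may be only part of what the source reports. "The series", "measured", "known", "first", "only" and "open" are said of these compounds alone.

Compound 1 `COc1cc2ncnc(Nc3cc(O)[nH]n3)c2cc1OC`: < 100000 nM
Compound 2 `COc1cc2ncnc(Nc3cc(-c4ccc(Cl)cc4)[nH]n3)c2cc1OC`: < 100000 nM

Both entries come from a functional assay on ZR-75-1 cells (Homo sapiens) for cytotoxicity, read by MTT assay (a higher number here means a weaker inhibitor, a lower number a stronger inhibitor), and neither is a number: each is a limit of the assay. Compound 2 therefore has no exact position, and its value of < 100000 nM is only a limit. Among the compounds with values here, the same holds for the whole series so far: the limit of < 100000 nM in this assay, at which 2 of the 2 values shown sit.

Compound 3 `COc1ccc(-c2cc(Nc3ncnc4cc(OC)c(OC)cc34)n[nH]2)cc1` keeps the shared core of compound 2 but carries 4-methoxyphenyl instead of 4-chlorophenyl. This places methoxy in place of chloro on an aromatic carbon, para to a large group: methoxy in place of chloro on an aromatic carbon.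

Within the data shown here, only one measured step bears on this change, and it concerns a different swap at the same ring carbon of the core: a step that the two limits leave unreadable from compound 1 to compound 2. It offers no size to carry forward, so no step beyond the scatter, in either direction, is expected in this assay. The estimated step is a step that the limit leaves unreadable from compound 2 to compound 3. A report as a limit is also expected to be quite possible for this compound. The expected value for compound 3 is 30000 nM, with an estimated range of 5000 nM to 100000 nM.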

Compound 3, half-maximal inhibitory concentration: < 100000 nM
Compound 3: no number, only a limit; the forecaster's own chance of this, stated with the estimate: 60%; the middle value is on the limit's open side.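

Compound 3, like compound 1 and compound 2, is reported in this assay only as a limit and not as a number, so no step among these compounds can be read. As far as these compounds go, the actual strength of each compound stays open, and so does whether 4-methoxyphenyl, 4-chlorophenyl and hydroxy differ at all in this measurement.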